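From 4-chlorophenyl to 3-hydroxyphenyl on a shared core

The source may hold more compounds than are shown below. What is called first, only, known or untested is meant among the compounds shown, and "the series" means these compounds.

Three compounds with different aryl groups on one shared core have been measured. In a functional assay on MCF7 cells (Homo sapiens) for cytotoxicity, read by MTT assay, with a stated time of 48 h (a lower number here means a stronger inhibitor, a higher number a weaker inhibitor), compound 1 `CC(C)=CCC/C(C)=C/CC/C(C)=C/CC[C@@H]1[C@@]2(C)CC/C(=N\OCc3cn(-c4ccc(Cl)cc4)nn3)C(C)(C)[C@@H]2CC[C@@]1(C)O` gives 12400 nM while compound 2 `CC(C)=CCC/C(C)=C/CC/C(C)=C/CC[C@@H]1[C@@]2(C)CC/C(=N\OCc3cn(-c4cccc(Br)c4)nn3)C(C)(C)[C@@H]2CC[C@@]1(C)O` gives 24800 nM and compound 3 `CC(C)=CCC/C(C)=C/CC/C(C)=C/CC[C@@H]1[C@@]2(C)CC/C(=N\OCc3cn(-c4cccc(C(F)(F)F)c4)nn3)C(C)(C)[C@@H]2CC[C@@]1(C)O` gives 21400 nM under the same conditions. Compound 1 stands within the scatter of both other compounds, so the three cannot be ranked.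

Compound 4 `CC(C)=CCC/C(C)=C/CC/C(C)=C/CC[C@@H]1[C@@]2(C)CC/C(=N\OCc3cn(-c4cccc(O)c4)nn3)C(C)(C)[C@@H]2CC[C@@]1(C)O` carries 3-hydroxyphenyl in place of 4-chlorophenyl on an aromatic nitrogen of a five-membered aromatic ring with 3 nitrogen. The counted difference is 3-hydroxyphenyl in place of 4-chlorophenyl on an aromatic nitrogen and the rest of the structure is unchanged. Going by the values given here, no measured compound carries a hydroxyl group, so there is no direct precedent for this exchange.

The nearest guides are the other aryl exchanges: a 2.0-fold higher number from compound 1 to compound 2 (0.30 log units; within the scatter) and a 1.7-fold higher number from compound 1 to compound 3 (0.24 log units; within the scatter) as well as a 1.2-fold lower number from compound 2 to compound 3 (0.06 log units; within the scatter) on the substituent alone. All three steps stay within the scatter. From the compounds shown here alone, no step beyond the scatter is therefore expected in this assay and the direction remains open, although the two measured departures from 4-chlorophenyl both gave higher numbers. The estimated change is a 1.5-fold higher number from compound 1 to compound 4 (0.16 log units; within the scatter) and it would remain within the scatter. For compound 4 the expected value is 18000 nM with an estimated range from 7000 nM to 45000 nM in this measurement.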

Compound 4, half-maximal inhibitory concentration: 9900 nM
The estimate for compound 4 lay 1.8-fold (0.26 log units) above the measured number; low and high end bracket the measured number.
By their numbers in this assay, from the lowest: compounds 4, 1, 3 and 2 (each within the scatter of the next, the first and the last beyond it).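

In this assay, a 1.3-fold lower number from compound 1 to compound 4 (0.10 log units; within the scatter) stays within the scatter, so 3-hydroxyphenyl and 4-chlorophenyl on the aromatic nitrogen cannot be told apart, even though the entering group brings a hydrogen-bond donor and a hydrogen-bond acceptor that the leaving group lacks. The series now also shows its first steps beyond the scatter, both modest, and both are exchanges on an aromatic carbon of the aryl group: a 2.2-fold lower number from compound 3 to compound 4 (0.33 log units; beyond the scatter) with hydroxy in place of trifluoromethyl, and a 2.5-fold lower number from compound 2 to compound 4 (0.40 log units; beyond the scatter) with hydroxy in place of bromo. Aryl exchanges at this position can therefore move the number measurably, but only slightly, and compound 4 at 9900 nM is separated from compound 2 and compound 3 without being separated from compound 1.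

No supporting data bear on why hydroxy gives a lower number than bromo or trifluoromethyl here. From the compounds shown here alone, it remains open whether an amine or a carboxylic acid in place of the hydroxyl group would extend these modest steps or fall back within the scatter of compound 1.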